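From Pyridin-2-yl to Pyridin-3-yl: a Step with Little Precedent

This account rests on a few compounds, and the source may have more. Where it says the series, first, only, none or still open, it means among the compounds named here.

Compound 1 `COc1cccc(S(=O)(=O)/C=C/c2ccccn2)c1` was tested in an ADME assay on BV-2 cells (Mus musculus) for cytotoxicity, with a stated time of 24 h, tested at 50 uM (a lower number here means a stronger effect, a higher number a weaker effect of the compound at the concentration tested), where compound 1 gives 98.9%. Among the compounds with values here, that is the highest of the two numbers known so far; its nearest neighbour, compound 2 `COc1cccc(S(=O)(=O)/C=C/c2ccc(Cl)cn2)c1`, gives 67.6%, and the only measured step, a number 31.3 percentage points lower from compound 1 to compound 2 (beyond the scatter), arises from chloro in place of hydrogen on an aromatic carbon. Compound 3 `COc1cccc(S(=O)(=O)/C=C/c2cccnc2)c1` has not yet been measured. It differs from compound 1 by pyridin-3-yl in place of pyridin-2-yl on a double-bonded chain carbon bound to a double-bonded chain carbon. Within the data shown here, no measured step concerns a change of this kind: the single step on hand adds a substituent rather than rejoining the same atoms, so it offers no direct guide. With nothing pointing either way, compound 3 is expected to show only a small step, a number 4.9 percentage points lower from compound 1 to compound 3 (within the scatter), not beyond the scatter. The estimate for compound 3 is therefore 94%, within a range from 78% to 100%.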

Compound 3, a percentage reported as activity, at one concentration (the size of the read-out at that concentration, not a potency): 90.8%
Estimate against measurement, compound 3: 3.2 percentage points above, within the range that was stated.
By their numbers in this assay, from the lowest: compound 2; then compounds 3 and 1 (each within the scatter of the next).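

In this assay, within the data shown here, pyridin-3-yl in place of pyridin-2-yl gives a number 8.1 percentage points lower from compound 1 to compound 3 (within the scatter) and provides the first measured change on a double-bonded chain carbon bound to a double-bonded chain carbon. Rejoining the same atoms thus leaves the read-out within the scatter, whereas chloro in place of hydrogen on an aromatic carbon gives a number 31.3 percentage points lower from compound 1 to compound 2 (beyond the scatter) and is so far the only change here that reaches beyond it. No measurement on hand bears on the reason for this result.

Going by these compounds, whether pyridin-4-yl or a plain phenyl ring at the same place would also stay within the scatter of compound 1 remains open. On these data alone, it is also open whether chloro on pyridin-3-yl would produce a step of the size seen with chloro on pyridin-2-yl.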